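The compounds below may be only part of what the source reports. "The series", "measured", "known", "first", "only" and "open" are said of these compounds alone.

Compound 3 `CC1=CCC[C@](C)(CC/C(C)=C/CC2=C(O)C(=O)C=C(N[C@H](C(=O)O)[C@H](C)O)C2=O)[C@@H]1C` carries the shared core with a 1-hydroxyethyl group on a saturated chain carbon bound to an amine nitrogen and a carbonyl carbon. In an ADME assay on L1210 cells (Mus musculus) for cytotoxicity, with a stated time of 48 h (on this read-out higher numbers stand for weaker inhibition and lower numbers for stronger inhibition), compound 3 gives only a limit, > 10 ug/mL, and not a number. Its nearest measured neighbour, compound 2 `CC1=CCC[C@](C)(CC/C(C)=C/CC2=C(O)C(=O)C=C(NCC(=O)O)C2=O)[C@@H]1C`, has hydrogen in that place and gives 3.5 ug/mL in this assay, so the step of an at least 2.8-fold higher number from compound 2 to compound 3 (0.45 log units; beyond the scatter) shows that adding the group weakened the inhibition. Compound 1 `C=C1[C@H](C)CCC[C@]1(C)CC/C(C)=C/CC1=C(O)C(=O)C=C(N[C@@H](C(=O)O)[C@H](C)O)C1=O` carries the same 1-hydroxyethyl group on a different terpene part and gives 4.6 ug/mL in this assay.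

Compound 4 `CC1=CCC[C@](C)(CC/C(C)=C/CC2=C(O)C(=O)C=C(N[C@@H](C(=O)O)[C@H](C)O)C2=O)[C@@H]1C` is the one still to be measured: the two compounds have the same atoms and bonds and differ only in configuration as drawn: 1 of 5 stereo elements differ; a stereocentre at a saturated chain carbon is drawn S in compound 3 and R in compound 4. Going by the values given here, none of the measured steps changes a configuration alone, so no step bears directly on this change. Compound 1, drawn with the same configuration at that carbon as compound 4, does give a number in this assay rather than a limit. On that basis compound 4 is expected at 6 ug/mL, with a likely range from 3 ug/mL to 12 ug/mL, so the step of an at least 1.6-fold lower number from compound 3 to compound 4 (0.22 log units; that floor lies within the scatter) is expected to move toward stronger inhibition, with a real chance that compound 4 again only reaches a limit.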

Compound 4, half-maximal inhibitory concentration: > 10 ug/mL
Compound 4: no number, only a limit; the forecaster's own chance of this, stated with the estimate: 30%; middle value at least 1.6-fold (0.22 log units) away from the limit.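

In this assay, compound 4 gives only a limit, just as compound 3 does, so the step between the two cannot be read and neither configuration can be ranked over the other: the limit of > 10 ug/mL in this assay, at which 2 of the 4 values shown sit. What can be read is the comparison with hydrogen: an at least 2.8-fold higher number from compound 2 to compound 4 (0.45 log units; beyond the scatter), so the 1-hydroxyethyl group goes with weaker inhibition on this terpene part in the R form as well as in the S form, as an at least 2.8-fold higher number from compound 2 to compound 3 (0.45 log units; beyond the scatter) had already shown for the S form. The terpene part also counts with the R configuration held fixed, as an at least 2.1-fold higher number from compound 1 to compound 4 (0.33 log units; beyond the scatter) shows, and compound 4 therefore does not follow the measurable result of its closest R-configured relative.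

Going by these compounds, how far the two configurations truly lie apart stays unknown, and any gap would come from configuration alone: the fact that compounds 3 and 4 differ only in the configuration as drawn. Also open, on these data alone, is how a hydroxymethyl group, an aminomethyl group or a longer chain would behave at this carbon, and whether the terpene part of compound 1 would keep its measurable inhibition with the S configuration.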